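The source may report more compounds than this note shows. Statements on the series, on what has been measured and on what is new or still open speak of the compounds shown alone.

Measured in an ADME assay on S9 fraction from liver (Rattus norvegicus) for metabolic stability, read by LC-MS, using NADPH, with a stated time of 30 min; on this read-out lower numbers stand for a less stable compound and higher numbers for a more stable compound:
compound 1 `CCCCCCCCc1ccc(OCC(=O)Cn2nnc(SC)n2)cc1`: < 5% (a limit of the assay, not a number)
compound 2 `CCCCCCCCc1ccc(OCC(=O)Cn2nnc(-c3ccccc3)n2)cc1`: 33%
compound 3 `CCCCCCCCc1ccc(OCC(=O)Cn2nnc(-c3cccc(S(=O)(=O)N(C)C)c3)n2)cc1`: 9%

Among the measured compounds shown here, of the two numbers in this assay, the lower belongs to compound 3, and the only other reading is the limit of compound 1. Next in the series is compound 4 `CCCCCCCCc1ccc(OCC(=O)Cn2nnc(C(=O)OC)n2)cc1`, with methoxycarbonyl in place of 3-(dimethylsulfamoyl)phenyl on an aromatic carbon. For the measured compounds named here, three measured steps bear on this change: a number at least 28 percentage points higher from compound 1 to compound 2 (beyond the scatter), a number at least 4 percentage points higher from compound 1 to compound 3 (that floor lies within the scatter) and a number 24 percentage points lower from compound 2 to compound 3 (beyond the scatter). Compound 4 loses the ring at this carbon, as compound 1 lacks one, and the ring of compound 3 gave only a number at least 4 percentage points higher from compound 1 to compound 3 (that floor lies within the scatter). No step beyond the scatter is therefore expected in this assay. The estimated step is a number 2 percentage points lower from compound 3 to compound 4 (within the scatter), slightly downward. For compound 4 the estimate is 7%, with an expected range of 2% to 22%.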

Compound 4, percent of the compound remaining: < 5%
Compound 4 ended at the assay's limit; the forecaster's own chance of this, stated with the estimate: 45%; middle value at least 2 percentage points from the limit.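

In this assay compound 4 gives < 5%, which is a limit of the assay and not a number. Methoxycarbonyl leaves a number at least 28 percentage points lower from compound 2 to compound 4 (beyond the scatter), and against the sulfamoyl-bearing ring it leaves a number at least 4 percentage points lower from compound 3 to compound 4 (that floor lies within the scatter); the step between the two limits cannot be read. Both ringless groups at this carbon now sit at the limit, and compound 2 alone stands clear of it by more than the scatter, with compound 3 going against any simple rule that a ring suffices: the limit of < 5% in this assay, at which 2 of the 4 values shown sit.

From the compounds shown here alone, whether phenyl itself or any ring carries the higher reading stays open. A pyridine ring or a longer alkyl chain at this carbon would separate the two.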